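The compounds below may be only part of what the source reports. "The series", "measured", "known", "first", "only" and "open" are said of these compounds alone.

Compound 1 `CCCCS(=O)(=O)Nc1cc(-c2ccc3ncnc(NCc4ccncc4)c3c2)cnc1OC` gives 5720 nM 
Compound 2 `COc1ncc(-c2ccc3ncnc(NCCCN(C)C)c3c2)cc1NS(=O)(=O)c1ccc(F)cc1F` gives 2200 nM 

Both compounds were tested in a functional assay on HCT-116 cells (Homo sapiens) for antiproliferative activity, read by sulforhodamine B assay, with a stated time of 72 h (a lower number here means a stronger inhibitor, a higher number a weaker inhibitor), and there compound 2 at 2200 nM holds the lower of the two numbers, with a gap to compound 1 that lies beyond the usual scatter. Compound 3 `CCCCS(=O)(=O)Nc1cc(-c2ccc3ncnc(NCCCN(C)C)c3c2)cnc1OC` has not yet been measured. It differs from compound 2 in one place, with butyl in place of 2,4-difluorophenyl on a sulfonyl sulfur, and butyl in place of 2,4-difluorophenyl on a sulfonyl sulfur gives the full count of that swap. For the measured compounds named here, no measured pair shows this change alone, so the guide is thin. A small shift in this assay towards a higher number is expected, resting only on the two numbers at hand. Estimated in numbers, this is a 1.6-fold higher number from compound 2 to compound 3 (0.20 log units; within the scatter) and it may not clear the scatter. For compound 3 the estimated value is 3500 nM with an expected range from 1000 nM to 11000 nM in this measurement.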

Compound 3, half-maximal inhibitory concentration: 490 nM
Compound 3: the middle estimate sits 7.1-fold (0.85 log units) above what was measured, outside the stated range (below it).
By their numbers in this assay, from the lowest: compound 3; then compound 2; then compound 1.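

In this assay, the group on the sulfonyl sulfur turns out to matter: butyl in place of 2,4-difluorophenyl gives a 4.5-fold lower number from compound 2 to compound 3 (0.65 log units; beyond the scatter), so the open chain without a ring holds the lower number of this pair. With butyl kept on the sulfonyl sulfur, a second change also counts: 2-(dimethylamino)ethyl in place of pyridin-4-yl on a saturated chain carbon bound to a nitrogen on an aromatic ring gives a 12-fold lower number from compound 1 to compound 3 (1.07 log units; beyond the scatter). Nothing measured here offers a reason for either step.

As far as these compounds go, it remains open whether methyl or a longer chain such as hexyl on the sulfonyl sulfur would move the number further, and whether plain phenyl would read like butyl or like 2,4-difluorophenyl. Also open, from the compounds shown here alone, is whether pyridin-4-yl and 2-(dimethylamino)ethyl would differ as much with 2,4-difluorophenyl on the sulfonyl sulfur.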